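From pyrrolidin-1-yl to 4-methylpiperidin-1-yl: cytotoxicity notes

A few compounds are considered here, and "the series" means these few. Any claim that something is new, unique, unknown or untested is made for them only; others in the source may bear on it.

In an ADME assay on MT4 cells (Homo sapiens) for cytotoxicity, read by MTT assay, with a stated time of 4 days (on this read-out higher numbers stand for lower toxicity in this test and lower numbers for higher toxicity in this test), compound 3 `Cc1c(Cc2c(F)cccc2F)nc(N2CCCC2)[nH]c1=O` gives > 82000 nM, which is a limit and not a number. Compound 1 `CCN(CC)c1nc(Cc2c(F)cccc2F)c(C)c(=O)[nH]1` gives > 81000 nM, also a limit. Compound 2 `CCCN(CCC)c1nc(Cc2c(F)cccc2F)c(C)c(=O)[nH]1` gives > 74000 nM, again a limit. Compound 3 thus stands alongside the other two compounds, and the series has no numeric read-out so far.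

Compound 4 `Cc1c(Cc2c(F)cccc2F)nc(N2CCC(C)CC2)[nH]c1=O` keeps the shared core and differs from compound 3 only in the amino group: 4-methylpiperidin-1-yl in place of pyrrolidin-1-yl on an aromatic carbon. The 4-methylpiperidin-1-yl group takes the place of pyrrolidin-1-yl on an aromatic carbon, between two ring nitrogen atoms.

Three measured steps involve changes at this same place: a step that the two limits leave unreadable from compound 1 to compound 2, a step that the two limits leave unreadable from compound 1 to compound 3 and a step that the two limits leave unreadable from compound 2 to compound 3. None of them has a readable size. They show only that diethylamino, dipropylamino and pyrrolidin-1-yl all end at a limit in this assay. No step beyond the scatter is therefore expected, in either direction, and another limit is the likeliest report. The expected change is an at least 1.1-fold lower number from compound 3 to compound 4 (0.06 log units; that floor lies within the scatter). For compound 4 the estimated value is 70000 nM, with an expected range from 30000 nM to 120000 nM.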

Compound 4, half-maximal cytotoxic concentration: > 75000 nM
Compound 4 was reported as a limit; the forecaster's own chance of this, stated with the estimate: 75%; at least 1.0-fold (0.02 log units) between middle value and limit.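

In this assay compound 4 gives > 75000 nM, which is a limit and not a number. Within the data shown here, with compound 1, compound 2 and compound 3 also reported as limits, no step to compound 4 can be read. The compounds shown leave open whether any amino group at this place gives a numeric value in this assay.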